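This account rests on a few compounds, and the source may have more. Where it says the series, first, only, none or still open, it means among the compounds named here.

Compound 1 `C=C(Br)C(=O)Nc1cccc(-c2cn3nc(-c4ccc(F)cc4)sc3n2)c1` gives 830 nM in a functional assay on CCRF-CEM cells (Homo sapiens) for inhibition, read by cell counting, with a stated time of 3 days; on this read-out higher numbers stand for weaker inhibition and lower numbers for stronger inhibition.
Compound 2 `C=C(Br)C(=O)Nc1cccc(-c2cn3nc(Cc4ccccc4)sc3n2)c1` gives 4200 nM.
Compound 3 `C=C(Br)C(=O)Nc1cccc(-c2cn3nc(-c4ccc(OCC)cc4)sc3n2)c1` gives 1400 nM.

Compound 3 has the second highest of the three numbers. Its nearest neighbour is compound 1, separated by a 1.7-fold higher number from compound 1 to compound 3 (0.23 log units; within the scatter), within the scatter; its furthest is compound 2, separated by a 3.0-fold lower number from compound 2 to compound 3 (0.48 log units; beyond the scatter), beyond the scatter. Compound 4 `C=C(Br)C(=O)Nc1cccc(-c2cn3nc(-c4ccc(C)cc4)sc3n2)c1` differs from compound 3 by methyl in place of ethoxy on an aromatic carbon. The step that bears on this is the exchange of one small group for another on the same aromatic carbon, a 1.7-fold higher number from compound 1 to compound 3 (0.23 log units; within the scatter), which stayed within the scatter; a 5.1-fold higher number from compound 1 to compound 2 (0.70 log units; beyond the scatter) concerns a different kind of change and is not directly comparable. A step within the scatter is therefore expected in this assay, with no firm direction. Compound 4 is estimated at 1000 nM (range 450 nM to 2500 nM), an expected step of a 1.4-fold lower number from compound 3 to compound 4 (0.15 log units; within the scatter).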

Compound 4, half-maximal inhibitory concentration: 1700 nM
Estimate against measurement, compound 4: 1.7-fold (0.23 log units) below; measured number inside the range.
By their numbers in this assay, from the lowest: compounds 1, 3 and 4 (each within the scatter of the next, the first and the last beyond it); then compound 2.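

Exchanging ethoxy for methyl on this ring carbon leaves the number in this assay without a readable change (a 1.2-fold higher number from compound 3 to compound 4 (0.08 log units; within the scatter)), so the 4-ethoxyphenyl and 4-methylphenyl groups cannot be separated here. Fluoro to methyl is the first exchange of a small group at this place to pass the scatter (a 2.0-fold higher number from compound 1 to compound 4 (0.31 log units; beyond the scatter)), though only modestly, and 4-methylphenyl, like 4-ethoxyphenyl, gives a lower number than benzyl (a 2.5-fold lower number from compound 2 to compound 4 (0.39 log units; beyond the scatter)). No available evidence explains these steps. 

Still open, as far as these compounds go, is how an amine, a carboxylic acid or a chain longer than ethoxy would read at this place. Whether chloro would track fluoro or methyl is also unresolved.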